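Trifluoromethyl in Place of Chloro on the Hydrazide Aryl Ring

The source may hold more compounds than are shown below. What is called first, only, known or untested is meant among the compounds shown, and "the series" means these compounds.

Compound 1 `Cc1cc2c(cc1C)C(Cl)=C(/C=N/NC(=O)c1cccc(Cl)c1)CCC2` reaches only the limit of a functional assay on IMR-32 cells (Homo sapiens) for inhibition, read by sulforhodamine B assay, with a stated time of 48 h (on this read-out lower numbers stand for stronger inhibition of growth and higher numbers for weaker inhibition of growth), giving > 100000 nM, which is a limit and not a number (the limit of > 100000 nM in this assay, at which 1 of the 2 values shown sits). Compound 2 `Cc1cc2c(cc1C)C(Cl)=C(/C=N/NC(=O)c1cccnc1)CCC2` gives 8400 nM in this assay, and an at least 11-fold lower number from compound 1 to compound 2 (1.07 log units; beyond the scatter) accompanies pyridin-3-yl replacing 3-chlorophenyl. Compound 3 `Cc1cc2c(cc1C)C(Cl)=C(/C=N/NC(=O)c1cccc(C(F)(F)F)c1)CCC2` differs from compound 1 by trifluoromethyl in place of chloro on an aromatic carbon. Among the compounds with values here, the one measured step exchanges the whole aryl group rather than the substituent on it, so it bears only loosely on this change. Compound 3 is expected to show a step of an at least 1.2-fold lower number from compound 1 to compound 3 (0.09 log units; that floor lies within the scatter), not beyond the scatter. Compound 3 is accordingly estimated at 80000 nM, within 20000 nM to 300000 nM.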

Compound 3, concentration for 50% growth inhibition: 7800 nM
Estimate against measurement, compound 3: 10-fold (1.01 log units) above; measured number below the stated range.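

In this assay, a change of the substituent alone, with the aromatic ring kept, is enough for a large step: trifluoromethyl in place of chloro gives an at least 12-fold lower number from compound 1 to compound 3 (1.10 log units; beyond the scatter). The earlier step exchanged the whole aryl group, so it could not show that this one position carries so large a change. The step is only a floor, as the value of compound 1 is a limit: the limit of > 100000 nM in this assay, at which 1 of the 3 values shown sits.

Going by these compounds, whether an amine, a carboxylic acid or a methoxy group at this position would give a similar step stays open.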